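A few compounds are considered here, and "the series" means these few. Any claim that something is new, unique, unknown or untested is made for them only; others in the source may bear on it.

Measured so far:
- compound 2, `COc1cccc(OC)c1C(=O)Nc1c[nH]nc1C(=O)NCc1ccccc1`: 50000 nM
- compound 1, `CO[C@H]1CC[C@H](NC(=O)c2n[nH]cc2NC(=O)c2ccc(F)cc2F)CC1`: 11000 nM

Among the measured compounds shown here, in an ADME assay on MRC5 cells (Homo sapiens) for inhibition, with a stated time of 72 h (on this read-out lower numbers stand for an effect already at smaller amounts and higher numbers for an effect only at larger amounts of compound), compound 2 gives 50000 nM, the highest of the two numbers known here. Compound 1, with a different core, gives 11000 nM, a lower number, and the gap between the two lies beyond the usual scatter of this assay. Compound 3, `COc1cccc(OC)c1C(=O)Nc1c[nH]nc1C(=O)NCCN1CCCC1`, has not yet been measured. It keeps the whole core of compound 2 and changes only one end: (pyrrolidin-1-yl)methyl in place of phenyl on a saturated chain carbon bound to an amide-type nitrogen. For the measured compounds named here, no measured pair shows this exact change, so its effect cannot be read from the data. With nothing to point in either direction, the step from compound 2 is expected to be small, a 1.3-fold lower number from compound 2 to compound 3 (0.10 log units; within the scatter), not clearly beyond the scatter. Compound 3 is therefore estimated to give 40000 nM in this assay, with a plausible range from 15000 nM to 100000 nM.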

Compound 3, half-maximal effective concentration: > 50000 nM
Compound 3: a limit, no number; the forecaster's own chance of this, stated with the estimate: 30%; middle value at least 1.2-fold (0.09 log units) from the limit.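

In this assay compound 3 gives > 50000 nM, which is a limit of the assay and not a number. Among the compounds shown here, this is the first measured change at this position: putting (pyrrolidin-1-yl)methyl in place of phenyl on a saturated chain carbon bound to an amide-type nitrogen gives a number no lower from compound 2 to compound 3 (the limit leaves the size open), so this swap of one ring for another brings no lower number. How large the step is cannot be read, because compound 3 sits at a limit: the limit of > 50000 nM in this assay, at which 1 of the 3 values shown sits.

The compounds shown leave open whether a morpholine ring or an open-chain dimethylamino group on the same chain would behave like the pyrrolidine ring. They also leave open whether a carboxylic acid at this end, or a longer chain carrying the pyrrolidine ring, would give a lower number than compound 2.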